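The compounds below may be only part of what the source reports. "The series", "measured", "known", "first", "only" and "open" are said of these compounds alone.

Three members of the series have been run in a functional assay on MCF7 cells (Homo sapiens) for inhibition, read by MTT assay, with a stated time of 48 h, tested at 7.5 ug/mL; on this read-out lower numbers stand for less inhibition of growth and higher numbers for more inhibition of growth at the one concentration tested. Compound 1 `O=c1cc(-c2ccccc2)oc2cc(N3COc4ccccc4C3)ccc12` gives 2.65% and compound 2 `O=c1cc(-c2ccccc2)oc2ccc(N3COc4ccccc4C3)cc12` gives 8.7%, two numbers that lie within the scatter of each other. Compound 3 `Cc1cccc2c1OCN(c1ccc3oc(-c4ccccc4)cc(=O)c3c1)C2` gives 30.4%, the highest of the three numbers: compound 2 sits nearest and compound 1 furthest, both beyond the scatter. Within the data shown here, the only single-point step measured so far runs a number 21.7 percentage points higher from compound 2 to compound 3 (beyond the scatter), methyl in place of hydrogen on an aromatic carbon.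

Compound 4 `O=c1cc(-c2ccccc2)oc2ccc(N3COc4c(Br)cccc4C3)cc12` is the next compound for this assay. Relative to compound 3 it carries bromo in place of methyl on an aromatic carbon. Among the measured compounds shown here, no measured pair shows a bromo entering or a methyl leaving, so the step from compound 2 to compound 3 is the only one that bears on it, and only loosely: it shows that a group of one heavy atom at this position moved the number beyond the scatter, but it says nothing about exchanging one such group for another. The expectation is therefore a step of small size in either direction, most likely within the scatter, which the estimated step of a number 1.6 percentage points higher from compound 3 to compound 4 (within the scatter) expresses. Compound 4 is accordingly expected to give 32%, with a range from 12% to 55%.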

Compound 4, percent growth inhibition at one concentration: "not active" (no number reported)
No number was reported for compound 4; there is nothing to compare the estimate with.
By their numbers in this assay, from the lowest: compounds 1 and 2 (each within the scatter of the next); then compound 3.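

Among these compounds, compound 4 is reported as not active in this assay with no number, so no step from compound 3 to compound 4 can be read. No available evidence bears on this result. The compounds shown leave open how far bromo and methyl in this place differ in growth inhibition.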